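A second trifluoromethyl on the terminal aryl of compound 1

A few compounds are considered here, and "the series" means these few. Any claim that something is new, unique, unknown or untested is made for them only; others in the source may bear on it.

Compound 1 `O=C(Nc1cccc(-n2cc(-c3ccncc3)c(-c3ccc(Cl)c(O)c3)n2)c1)Nc1cccc(C(F)(F)F)c1` is known in a functional assay on OVCAR-5 cells (Homo sapiens) for inhibition, read by sulforhodamine B assay, with a stated time of 48 h (on this read-out lower numbers stand for higher toxicity in this test and higher numbers for lower toxicity in this test), only as a limit of the assay: compound 1 gives > 32500 nM. Compound 2 `O=C(Nc1cccc(-n2cc(-c3ccncc3)c(-c3ccc(Cl)c(O)c3)n2)c1)Nc1ccc(Cl)c(Cl)c1` likewise stands at a limit rather than a number. In this assay compound 2 gives > 32500 nM. The step that the two limits leave unreadable from compound 1 to compound 2 therefore cannot be sized, since both values sit at the limit of > 32500 nM in this assay, at which 2 of the 2 values shown sit.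

Compound 3 `O=C(Nc1cccc(-n2cc(-c3ccncc3)c(-c3ccc(Cl)c(O)c3)n2)c1)Nc1cc(C(F)(F)F)cc(C(F)(F)F)c1` differs from compound 1 by trifluoromethyl in place of hydrogen on an aromatic carbon. Within the data shown here, the only measured step that bears on this change is the one from compound 1 to compound 2, which exchanges the same aryl group, and it is unreadable; no measured step gives a number at all. Compound 3 is therefore expected to stay at the limit, with a step that the limit leaves unreadable from compound 1 to compound 3 as the estimated step, not beyond the scatter. For compound 3 the estimate in this assay is 40000 nM, within a range of 15000 nM to 100000 nM.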

Compound 3, concentration lethal to 50% of the cells: 4700 nM
Beside the measured number, compound 3's estimate is 8.5-fold (0.93 log units) above it, outside the stated range (below it).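

In this assay, among these compounds, trifluoromethyl in place of hydrogen on an aromatic carbon, meta to a trifluoromethyl group, gives the first readable step: an at least 6.9-fold lower number from compound 1 to compound 3 (0.83 log units; beyond the scatter). This position on the aryl group is therefore one where a single change moves the read-out toward higher toxicity in this test, which the exchange of aryl groups between compound 1 and compound 2 could not show. Among the compounds shown here, compound 3 is the only compound here with a number rather than a limit: the limit of > 32500 nM in this assay, at which 2 of the 3 values shown sit.

Going by these compounds, compound 1 stands at a limit, so the full size of the step stays open. Also open, on these data alone, is whether an amine, a methoxy group or a nitrile at this place would move the read-out as trifluoromethyl does.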